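Acyl for Sulfonyl on the Ring Nitrogen of Compound 3

This account rests on a few compounds, and the source may have more. Where it says the series, first, only, none or still open, it means among the compounds named here.

Compound 1, `COc1c2ccccc2nn1-c1cccc(I)c1`, in an assay on isolated protein (urine) for inhibition of Myeloperoxidase (Homo sapiens), read by spectrophotometry; a higher number here means a weaker inhibitor, a lower number a stronger inhibitor: compound 1 gives 1660 nM.
Compound 2, `CC(C)n1[nH]c2ccccc2c1=O`: compound 2 gives 660 nM.
Compound 3, `CC(C)n1c(=O)c2ccccc2n1S(C)(=O)=O`: compound 3 gives only a limit of the assay, > 10000 nM.

From the compounds shown here alone, compound 3 therefore stands at the edge of what the assay reports; its true number is unknown beyond (the limit of > 10000 nM in this assay, at which 1 of the 3 values shown sits). Among the compounds with values here, the one step that reaches it, an at least 15-fold higher number from compound 2 to compound 3 (1.18 log units; beyond the scatter), shows that covering the hydrogen on the aromatic nitrogen of compound 2 with methylsulfonyl cost a great deal of inhibition. Within the data shown here, compound 1 belongs to a different core and offers no step for comparison.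

Compound 4, `CC(=O)n1c2ccccc2c(=O)n1C(C)C`, differs from compound 3 by acetyl in place of methylsulfonyl on an aromatic nitrogen. Among the measured compounds shown here, the substituent that enters is again a carbonyl-type group on the same nitrogen, so the only measured step bearing on it points toward weak inhibition remaining; whether acetyl sits nearer to the bare hydrogen of compound 2 cannot be told from these data. Compound 4 is expected to stay weak, with an estimated step of an at least 1.2-fold lower number from compound 3 to compound 4 (0.09 log units; that floor lies within the scatter). The estimated value for compound 4 is 8000 nM, expected between 2000 nM and 30000 nM, with a fair chance that only a limit is reported.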

Compound 4, half-maximal inhibitory concentration: > 10000 nM
Compound 4 was reported as a limit; the forecaster's own chance of this, stated with the estimate: 45%; middle value at least 1.2-fold (0.09 log units) from the limit.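

In this assay, acetyl on the aromatic nitrogen gives an at least 15-fold higher number from compound 2 to compound 4 (1.18 log units; beyond the scatter), so the large loss seen with methylsulfonyl in compound 3 is not confined to that one group. Of the three groups shown on this nitrogen, only the hydrogen of compound 2 gives a value that is an actual number rather than a limit. The step between compound 3 and compound 4 cannot be read, so the two groups cannot be ranked against each other, and both compounds remain at the edge of what the assay reports: the limit of > 10000 nM in this assay, at which 2 of the 4 values shown sit.

From the compounds shown here alone, how far beyond that limit either compound truly lies remains unknown. Also open, going by these compounds, is whether a plain methyl group, a longer chain or a chain ending in an amine on this nitrogen would keep any of the inhibition of compound 2.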